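Methyl in Place of Phenyl on a Shared Core

A few compounds are considered here, and "the series" means these few. Any claim that something is new, unique, unknown or untested is made for them only; others in the source may bear on it.

Measured so far in a functional assay for inhibition, with Homo sapiens as the target; a higher number here means a weaker inhibitor, a lower number a stronger inhibitor:
compound 1, `CCCc1nnc(O)n2c(CCC)nc(C)c12`, gives 16000 nM
compound 2, `CCCc1nc(C)c2c(CC)nnc(O)n12`, gives 15600 nM
compound 3, `CCCc1nc(C)c2c(-c3ccccc3)nnc(O)n12`, gives > 48000 nM

Compound 3 stands at the limit of > 48000 nM in this assay, at which 1 of the 3 values shown sits, so its number is only a limit, not a measured value. Compounds 1 and 2 sit close together, and the step of a 1.0-fold lower number from compound 1 to compound 2 (0.01 log units; within the scatter) changes nothing beyond the scatter.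

Compound 4, `CCCc1nc(C)c2c(C)nnc(O)n12`, differs from compound 3 by methyl in place of phenyl on an aromatic carbon. For the measured compounds named here, two measured steps bear on this change in the opposite direction: an at least 3.0-fold higher number from compound 1 to compound 3 (0.47 log units; beyond the scatter) and an at least 3.0-fold higher number from compound 2 to compound 3 (0.48 log units; beyond the scatter). Going back from phenyl to a small alkyl group is therefore expected to lower the number, giving an expected step of an at least 2.4-fold lower number from compound 3 to compound 4 (0.38 log units; beyond the scatter). For compound 4 the estimate is 20000 nM, in a range from 8000 nM to 50000 nM.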

Compound 4, half-maximal inhibitory concentration: 14000 nM
For compound 4 the middle estimate is 1.4-fold (0.15 log units) above the measured one, and the stated range covers the measured number.
By their numbers in this assay, from the lowest: compounds 4, 2 and 1 (each within the scatter of the next). At a limit, above all of these: compound 3.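

Putting methyl in place of phenyl on this aromatic carbon gives an at least 3.4-fold lower number from compound 3 to compound 4 (0.53 log units; beyond the scatter) in this assay, although the value for compound 3 is only a limit: the limit of > 48000 nM in this assay, at which 1 of the 4 values shown sits.

Among the small alkyl groups, chain length at this position makes no difference beyond the scatter, with a 1.1-fold lower number from compound 2 to compound 4 (0.05 log units; within the scatter) and a 1.1-fold lower number from compound 1 to compound 4 (0.06 log units; within the scatter). Of the four compounds, only the phenyl group of compound 3 stands apart from the others.

Open, going by these compounds, is whether a chain longer than propyl, an amine or a carboxylic acid at this position would give a stronger inhibitor. Also open, on these data alone, is whether any other ring would behave like phenyl.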